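A Larger Group on a Compound at the Assay Limit

The compounds below may be only part of what the source reports. "The series", "measured", "known", "first", "only" and "open" are said of these compounds alone.

Of the compounds shown here, three have been measured in an ADME assay on HEK293 cells (Homo sapiens) for cytotoxicity, with a stated time of 72 h; on this read-out higher numbers stand for an effect only at larger amounts of compound and lower numbers for an effect already at smaller amounts. Compound 1 `C=C[C@@](C)(/C=C/c1ccc(O)cc1)CCC(O)C(C)(C)O` gives > 36600 nM, which is a limit of the assay and not a number. Compound 2 `C=C[C@@](C)(/C=C/c1ccc(O)cc1)CC/C=C/C(=O)c1ccccc1` gives > 36600 nM, which is also a limit. Compound 3 `C=C[C@@](C)(/C=C/c1ccc(O)c(/C=C/C#N)c1)CCC=C(C)C` gives > 36600 nM, again a limit rather than a number. All the data so far come down to the limit of > 36600 nM in this assay, at which 3 of the 3 values shown sit, so compound 3 has no exact value and cannot be ranked against the other two.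

Compound 4 `C=C[C@@](C)(/C=C/c1ccc(O)c(/C=C/c2ccc(Cl)cc2)c1)CCC=C(C)C` differs from compound 3 in one place, where 4-chlorophenyl stands in place of cyano on a double-bonded chain carbon bound to a double-bonded chain carbon. Cut one bond further out, this is 2-cyanoethenyl to 2-(4-chlorophenyl)ethenyl, and the count reads (4-chlorophenyl in place of cyano on a double-bonded chain carbon bound to a double-bonded chain carbon).

Within the data shown here, no measured pair shows what this exchange does. With compound 3 at > 36600 nM, a limit, the expectation in this assay is no step beyond the usual scatter, with any small shift leaning toward lower numbers. The expected step of an at least 1.2-fold lower number from compound 3 to compound 4 (0.08 log units; that floor lies within the scatter) is therefore small. For compound 4 the estimated value is 30000 nM, with an expected range from 12000 nM to 70000 nM.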

Compound 4, half-maximal effective concentration: > 36600 nM
Compound 4 was reported as a limit (the forecaster's own chance of this, stated with the estimate: 70%); middle value at least 1.2-fold (0.08 log units) away from the limit.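

In this assay compound 4 gives > 36600 nM, a limit of the assay and not a number. Among these compounds, compound 3 also stands at a limit, so no step from compound 3 to compound 4 can be read. The compounds shown leave open whether 4-chlorophenyl in place of cyano changes the value at all, and at what amount any of them acts: the limit of > 36600 nM in this assay, at which 4 of the 4 values shown sit.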